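The compounds below may be only part of what the source reports. "The series", "measured", "known", "first", "only" and "open" are said of these compounds alone.

Measured compounds:

compound 1 `COc1ccc(-c2cc3nccc(-c4cc(OC)c(OC)c(OC)c4)n3n2)cc1N` — 88 nM
compound 2 `COc1cc(-c2ccnc3cc(-c4ccc(C)cc4)nn23)cc(OC)c1OC` — 21 nM
compound 3 `COc1ccc(-c2cc3nccc(-c4cc(OC)c(OC)c(OC)c4)n3n2)cc1F` — 3950 nM

All three share one core and differ only in the phenyl ring attached to it. In a functional assay on B16-F0 cells (Mus musculus) for inhibition, read by CCK-8 assay, with a stated time of 48 h (a lower number here means a stronger inhibitor, a higher number a weaker inhibitor), compound 2 gives the lowest of the three numbers: the step of a 4.2-fold lower number from compound 1 to compound 2 (0.62 log units; beyond the scatter) is modest, while a 190-fold higher number from compound 2 to compound 3 (2.27 log units; beyond the scatter) and a 45-fold higher number from compound 1 to compound 3 (1.65 log units; beyond the scatter) are large, so the substituents on this phenyl ring clearly matter.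

Compound 4 `COc1cc(-c2ccnc3cc(-c4ccc(-c5cnn(C)c5)cc4)nn23)cc(OC)c1OC` keeps everything from compound 2 except one group: 1-methyl-1H-pyrazol-4-yl in place of methyl on an aromatic carbon.

Among the measured compounds shown here, no measured step puts a ring in this position, so none bears on it directly. The measured steps only show that swapping small groups on this ring can move the number a little (from compound 1 to compound 2) or a lot (toward compound 3). A much larger group with two hydrogen-bond acceptors is a bigger change than any of those, in an unknown direction. The expectation is therefore a step of a 1.9-fold higher number from compound 2 to compound 4 (0.28 log units; within the scatter) in this assay with wide uncertainty; compound 4 is estimated at 40 nM, between 8 nM and 250 nM.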

Compound 4, half-maximal inhibitory concentration: 1240 nM
For compound 4 the middle estimate is 31-fold (1.49 log units) below the measured one; measured number above the stated range.
By their numbers in this assay, from the lowest: compound 2; then compound 1; then compound 4; then compound 3.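

Replacing methyl with 1-methyl-1H-pyrazol-4-yl on this aromatic carbon of the phenyl ring gives a 59-fold higher number from compound 2 to compound 4 (1.77 log units; beyond the scatter) in this assay. The earlier compounds shown here showed that this phenyl ring responds to changes in its small groups, whereas this step shows that a much larger group carrying a second aromatic ring can also cost a great deal of inhibition at this one position, so the low number of compound 2 does not carry over to this larger replacement. No measurement shown here explains why the number rises so far.

This single step changes several things at once, adding five heavy atoms overall, a five-membered aromatic ring and 2 hydrogen-bond acceptors, so the compounds shown cannot tell which of these changes matters. A plain phenyl group at the same carbon would keep an added aromatic ring without the two nitrogens, while an ethyl group would extend the methyl only slightly, and the two together would show how the number changes between the small methyl and the full 1-methyl-1H-pyrazol-4-yl group.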